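Dichlorophenyl for Phenyl on a Longer-Chain Histamine Antagonist

The source may hold more compounds than are shown below. What is called first, only, known or untested is meant among the compounds shown, and "the series" means these compounds.

Measured compounds:
compound 1, `N=C(NCCCc1c[nH]cn1)NCCC(c1ccccc1)c1ccccn1`, in a functional assay on ileum for antagonist activity at histamine H1 receptor (Cavia porcellus) (on this read-out lower numbers stand for lower potency and higher numbers for higher potency (the scale is a negative logarithm)), gives 7.01
compound 2, `N=C(NCCCc1c[nH]cn1)NCCCC(c1ccccc1)c1ccccn1`, in this assay gives 6.06
compound 3, `N=C(NCCCc1c[nH]cn1)NCCC(c1ccc(Cl)c(Cl)c1)c1ccccn1`, in this assay gives 7.1

Compound 3 differs from compound 1 by 3,4-dichlorophenyl in place of phenyl on a saturated chain carbon bound to an aromatic carbon and a saturated chain carbon, and this change gave a number 0.09 log units higher from compound 1 to compound 3 (within the scatter). Compound 2 stands lowest of the three in this assay; the difference between its core and that of compound 1 is not broken down here. Compound 4, `N=C(NCCCc1c[nH]cn1)NCCCC(c1ccc(Cl)c(Cl)c1)c1ccccn1`, has not been measured. It differs from compound 2 by 3,4-dichlorophenyl in place of phenyl on a saturated chain carbon bound to an aromatic carbon and a saturated chain carbon, the same change made from compound 1 to compound 3. Among the compounds with values here, the step from compound 2 to compound 4 in this assay is expected to be a number 0.09 log units higher from compound 2 to compound 4 (within the scatter), resting on the small step of a number 0.09 log units higher from compound 1 to compound 3 (within the scatter) seen in the one measured pair. Compound 4 is therefore estimated at 6.15, most likely between 5.7 and 6.6.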

Compound 4, negative logarithm of the antagonist equilibrium constant: 7.46
The estimate for compound 4 lay 1.31 log units below the measured number; the whole stated range lies below it.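

Putting 3,4-dichlorophenyl in place of phenyl gave a number 1.40 log units higher from compound 2 to compound 4 (beyond the scatter) in this assay. The size of this change therefore did not carry over from one core to the other: the same change on two cores in this assay, a number 0.09 log units higher (within the scatter) from compound 1 to compound 3 and a number 1.40 log units higher (beyond the scatter) from compound 2 to compound 4, 1.31 log units apart, beyond the scatter of two such steps

This shows that, for these two pairs, the effect of the change depends on the core it is made on, but it does not show what in the core is responsible or how the change would behave on any further core.

The compounds shown leave open whether a phenyl carrying a single chlorine would give a large step on the core of compound 2. They also leave open what a still longer chain would do to the step.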